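This account rests on a few compounds, and the source may have more. Where it says the series, first, only, none or still open, it means among the compounds named here.

Measured so far:
Compound 1 `O=C(OCC(F)(F)F)c1ccsc1NC(=O)[C@@H]1CCCN1` gives 109 ug/mL in a functional assay on HeLa cells (Homo sapiens) for inhibition; a lower number here means a stronger inhibitor of growth, a higher number a weaker inhibitor of growth.
Compound 2 `COC(=O)c1ccsc1NC(=O)[C@H]1CCCN1` gives 91.4 ug/mL in this assay.

Both compounds have the shared core and differ only in the group that sits on a saturated chain carbon bound to an oxygen next to a carbonyl group. Compound 1 has the highest of the two numbers in this assay, but its nearest neighbour, compound 2, lies within the usual scatter of repeated measurements, so the two values cannot be told apart: both compounds are weak inhibitors of growth.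

Compound 3 `CCOC(=O)c1ccsc1NC(=O)[C@@H]1CCCN1` has not been measured. It differs from compound 1 in one place: methyl in place of trifluoromethyl on a saturated chain carbon bound to an oxygen next to a carbonyl group. Among the measured compounds shown here, no measured pair shows this exact change, so nothing here tells how large a step it makes. The step of a 1.1-fold lower number from compound 1 to compound 3 (0.04 log units; within the scatter) is expected to be small, no larger than the scatter and in no clear direction, because compound 1 gives 109 ug/mL and compound 2 gives 91.4 ug/mL despite a change in the same part of the structure. Compound 3 is estimated at 100 ug/mL, with a range of 50 ug/mL to 200 ug/mL.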

Compound 3, concentration for 50% growth inhibition: 35.3 ug/mL
For compound 3 the middle estimate is 2.8-fold (0.45 log units) above the measured one; measured number outside the range, below it.
By their numbers in this assay, from the lowest: compound 3; then compounds 2 and 1 (each within the scatter of the next).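

In this assay, putting methyl in place of trifluoromethyl on a saturated chain carbon bound to an oxygen next to a carbonyl group gives a 3.1-fold lower number from compound 1 to compound 3 (0.49 log units; beyond the scatter), a modest move towards stronger inhibition of growth. Compounds 1 and 2 alone could not be told apart, so they gave no sign that this part of the structure could shift the number, whereas this single-place change shows that it can, and that going from 2,2,2-trifluoroethyl to ethyl is enough to do so. Nothing measured here accounts for the step, so the reason for it remains unknown.

Among the compounds shown here, this is only one change at one position, so it does not show whether the number would keep falling with a longer chain such as propyl or butyl, or would rise again. Nor do the compounds shown tell how this position would respond to a quite different group, such as an amine or a carboxylic acid, in place of the ethyl chain.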